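Replacing a Pentyl Chain with a Dimethylcyclohexyl Ring

The source may report more compounds than this note shows. Statements on the series, on what has been measured and on what is new or still open speak of the compounds shown alone.

Three compounds have been measured in an assay on CHO cells for antagonist activity at transient receptor potential cation channel subfamily V member 1 (Homo sapiens), read by FLIPR and calcium flux; on this read-out higher numbers stand for weaker inhibition and lower numbers for stronger inhibition:
compound 1 `CCCCCc1nc(C(F)(F)F)ccc1CNC(=O)C(C)c1ccc(NS(C)(=O)=O)c(F)c1` gives 1 nM
compound 2 `CCCCCCc1nc(C(F)(F)F)ccc1CNC(=O)C(C)c1ccc(NS(C)(=O)=O)c(F)c1` gives 1.6 nM
compound 3 `CC(C(=O)NCc1ccc(C(F)(F)F)nc1CCC(C)(C)C)c1ccc(NS(C)(=O)=O)c(F)c1` gives 0.6 nM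

Compound 1 holds the second highest of these three numbers. Its neighbours are close: a 1.6-fold higher number from compound 1 to compound 2 (0.20 log units; within the scatter), and a 1.7-fold lower number from compound 1 to compound 3 (0.22 log units; within the scatter). Going by the values given here, the only step beyond the scatter is a 2.7-fold lower number from compound 2 to compound 3 (0.43 log units; beyond the scatter), a modest one.

Compound 4 `CC(C(=O)NCc1ccc(C(F)(F)F)nc1C1CCC(C)(C)CC1)c1ccc(NS(C)(=O)=O)c(F)c1` arises from compound 1 by 4,4-dimethylcyclohexyl in place of pentyl on an aromatic carbon. The measured steps all changed a saturated chain at this same ring carbon by small amounts, and none moved this assay far. A ring entering in place of a chain is a larger change than any of those, so the expectation is uncertain, but compound 4 is expected to stay near compound 1, with a step of a 1.2-fold higher number from compound 1 to compound 4 (0.08 log units; within the scatter). Compound 4 is therefore estimated at 1.2 nM, with a range from 0.3 nM to 5 nM.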

Compound 4, inhibition constant: 0.4 nM
For compound 4 the middle estimate is 3.0-fold (0.48 log units) above the measured one; low and high end bracket the measured number.
By their numbers in this assay, from the lowest: compounds 4, 3, 1 and 2 (each within the scatter of the next, the first and the last beyond it).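

A ring is shown here for the first time on this aromatic carbon, and in this assay it does not cost inhibition: the number falls against the straight chains (a 2.5-fold lower number from compound 1 to compound 4 (0.40 log units; beyond the scatter); a 4.0-fold lower number from compound 2 to compound 4 (0.60 log units; beyond the scatter)). The ring cannot be told apart from the branched 3,3-dimethylbutyl chain (a 1.5-fold lower number from compound 3 to compound 4 (0.18 log units; within the scatter)). No evidence at hand accounts for these steps.

Plain cyclohexyl, without the two methyl groups, would show whether the ring or the methyls matter. A piperidine ring in the same place, carrying an amine nitrogen, remains an open case.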